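The compounds below may be only part of what the source reports. "The series", "measured", "known", "first", "only" and "open" are said of these compounds alone.

Measured compounds in an ADME assay on L6 cells (Rattus norvegicus) for cytotoxicity; on this read-out higher numbers stand for weaker inhibition and lower numbers for stronger inhibition:
compound 1 `CCCCCC(=O)NCCCN1CCN(CCCNc2ccnc3cc(Cl)ccc23)CC1`: "not determined" (no result reported)
compound 2 `O=C(CCCc1c[nH]c2ccccc12)NCCCN1CCN(CCCNc2ccnc3cc(Cl)ccc23)CC1`: 6500 nM
compound 3 `O=C(CCCOc1ccccc1)NCCCN1CCN(CCCNc2ccnc3cc(Cl)ccc23)CC1`: 9300 nM

Compound 1 stands without a number in this assay; its entry reads only "not determined" (no result reported). The two compounds that do carry numbers, compound 2 and compound 3, share the core and the amide-linked chain of compound 1 and differ from each other only in the group on that chain: a 1.4-fold higher number from compound 2 to compound 3 (0.16 log units; within the scatter). Among the compounds with values here, this is the sole measured step in the set, and it lies within the scatter.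

Compound 4 `CCOc1ccc(C(=O)NCCCN2CCN(CCCNc3ccnc4cc(Cl)ccc34)CC2)cc1` is compound 1 altered at the carbonyl carbon: 4-ethoxyphenyl in place of pentyl on a carbonyl carbon. Within the data shown here, no measured step covers an exchange of this kind. Among the measured compounds shown here, the one available step concerns a group further out on a saturated chain and was within the scatter, so it offers no direction for a change at the carbonyl carbon. With no number for compound 1 to step from, the expectation for compound 4 in this assay can rest only on the level shown by compound 2 and compound 3 and on the absence of any shift beyond the scatter between them. Compound 4 is therefore expected to give about 8000 nM in this assay, with a range from 3000 nM to 25000 nM.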

Compound 4, half-maximal inhibitory concentration: 5300 nM
For compound 4 the middle estimate is 1.5-fold (0.18 log units) above the measured one; the range from low to high includes it.
By their numbers in this assay, from the lowest: compounds 4, 2 and 3 (each within the scatter of the next).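

In this assay, the carbonyl carbon now carries an aromatic ring of carbon only through 4-ethoxyphenyl, and the number stays level with those of the two amides bearing a substituted propyl chain (a 1.8-fold lower number from compound 3 to compound 4 (0.24 log units; within the scatter); a 1.2-fold lower number from compound 2 to compound 4 (0.09 log units; within the scatter)), both steps within the scatter. The earlier compounds shown here showed only an exchange further out on a saturated chain, whereas these steps change the whole group on the carbonyl carbon, and neither 3-phenoxypropyl nor 3-(1H-indol-3-yl)propyl separates from 4-ethoxyphenyl beyond the scatter. The step from compound 1 to compound 4 cannot be read, compound 1 having no number, and no evidence at hand bears on this result.

Open, as far as these compounds go, is whether an amine or a carboxylic acid on the aromatic ring of 4-ethoxyphenyl, or a longer chain in place of its ethoxy group, would move the number beyond the scatter in this assay. Also open, from the compounds shown here alone, is where a plain alkyl amide such as the pentyl group of compound 1 stands against compound 2, compound 3 and compound 4.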